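This account rests on a few compounds, and the source may have more. Where it says the series, first, only, none or still open, it means among the compounds named here.

Three analogues on a shared core have been run in a functional assay on M21 cells (Homo sapiens) for antiproliferative activity, read by sulforhodamine B assay, with a stated time of 48 h; on this read-out higher numbers stand for weaker inhibition and lower numbers for stronger inhibition. Compound 1 `Cc1cccc(NS(=O)(=O)c2ccc(N3CCNC3=O)cc2)c1` gives 69 nM, compound 2 `O=C1NCCN1c1ccc(S(=O)(=O)Nc2ccccc2)cc1` gives 200 nM, and compound 3 `O=C1NCCN1c1ccc(S(=O)(=O)Nc2cccc(Br)c2)cc1` gives 59 nM. On the numbers shown compound 3 gives the lowest; the nearest step is a 1.2-fold lower number from compound 1 to compound 3 (0.07 log units; within the scatter), the furthest is a 3.4-fold lower number from compound 2 to compound 3 (0.53 log units; beyond the scatter). Compound 4 `Cc1ccccc1NS(=O)(=O)c1ccc(N2CCNC2=O)cc1` carries 2-methylphenyl in place of 3-bromophenyl on a sulfonamide nitrogen. Within the data shown here, the steps that bear on this are a 1.2-fold lower number from compound 1 to compound 3 (0.07 log units; within the scatter), showing bromo and methyl close together, and a 2.9-fold higher number from compound 1 to compound 2 (0.46 log units; beyond the scatter) together with a 3.4-fold lower number from compound 2 to compound 3 (0.53 log units; beyond the scatter), showing that the bare phenyl gives a higher number; no measured step speaks to 2-methylphenyl. A small step is therefore expected, a 1.7-fold higher number from compound 3 to compound 4 (0.23 log units; within the scatter), if anything toward a higher number. Compound 4 is estimated at 100 nM in this assay, with a range of 40 nM to 250 nM.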

Compound 4, half-maximal inhibitory concentration: 150 nM
Compound 4: middle estimate off by 1.5-fold (0.18 log units), on the low side; low and high end bracket the measured number.
By their numbers in this assay, from the lowest: compounds 3 and 1 (each within the scatter of the next); then compounds 4 and 2 (each within the scatter of the next).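

On the sulfonamide nitrogen, the place of the methyl on the phenyl counts: 2-methylphenyl in place of 3-methylphenyl gives a shift beyond the scatter (a 2.2-fold higher number from compound 1 to compound 4 (0.34 log units; beyond the scatter)), and 2-methylphenyl also separates from 3-bromophenyl (a 2.5-fold higher number from compound 3 to compound 4 (0.41 log units; beyond the scatter)). Adding a methyl to the bare phenyl is therefore not enough on its own, as 2-methylphenyl stays within the scatter of it (a 1.3-fold lower number from compound 2 to compound 4 (0.12 log units; within the scatter)). Nothing available explains this difference.

Going by these compounds, whether 2-bromophenyl tracks 2-methylphenyl remains open. So does the outcome with a methoxy group, an amine or a carboxylic acid on the phenyl.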